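The compounds below may be only part of what the source reports. "The series", "measured", "known", "first", "only" and "open" are said of these compounds alone.

Three amides that share a vanillyl-type head and a long unsaturated tail were measured in an assay on HEK293 cells for antagonist activity at transient receptor potential cation channel subfamily V member 2 (Rattus norvegicus), read by fluorescence and calcium flux, with a stated time of 5 min; a lower number here means a stronger inhibitor, a higher number a weaker inhibitor. Compound 1 `CCCCC/C=C\C/C=C\CCCCCCCC[Se]CCC(=O)NCc1ccc(O)c(OC)c1` gives 1400 nM, compound 2 `CCCCCCCC/C=C\CCCCCCCC[Se]CCC(=O)NCc1ccc(O)c(OC)c1` gives 1800 nM, and compound 3 `CCCCCCCC/C=C\CCCCCCCCSCCC(=O)NCc1ccc(O)c(OC)c1` gives 2500 nM. The change from compound 2 to compound 1, (hept-1-en-1-yl in place of heptyl on a saturated chain carbon bound to a double-bonded chain carbon), produced a 1.3-fold lower number from compound 2 to compound 1 (0.11 log units; within the scatter). Compound 3 and compound 2 differ in their cores; that difference between the two cores is not broken down here. The numbers for compound 3 and compound 2 lie within the scatter of each other in this assay, as do those for compound 3 and compound 1, so the three measured compounds cannot be ordered.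

Compound 4 `CCCCC/C=C\C/C=C\CCCCCCCCSCCC(=O)NCc1ccc(O)c(OC)c1` has not yet been measured. It arises from compound 3 by hept-1-en-1-yl in place of heptyl on a saturated chain carbon bound to a double-bonded chain carbon, the same change, in the same place, that led from compound 2 to compound 1. Because that change gave only a 1.3-fold lower number from compound 2 to compound 1 (0.11 log units; within the scatter), a step of similar size is expected here, and the estimated step from compound 3 to compound 4 is a 1.3-fold lower number from compound 3 to compound 4 (0.12 log units; within the scatter). Compound 4 is therefore expected to give about 1900 nM in this assay, most likely between 900 nM and 4000 nM.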

Compound 4, half-maximal inhibitory concentration: 1400 nM
For compound 4 the middle estimate is 1.4-fold (0.13 log units) above the measured one; the range from low to high includes it.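

Carried over to the core of compound 3, hept-1-en-1-yl in place of heptyl gave a 1.8-fold lower number from compound 3 to compound 4 (0.25 log units; within the scatter) in this assay. Set beside the earlier step on the core of compound 2, this step does not differ from it: the same change on two cores in this assay, a 1.3-fold lower number (0.11 log units; within the scatter) from compound 2 to compound 1 and a 1.8-fold lower number (0.25 log units; within the scatter) from compound 3 to compound 4, 1.4-fold (0.14 log units) apart, within the scatter of two such steps. The change therefore carries from one core to the other with no detectable difference, but each step lies within the scatter, so neither shows that the change alters inhibition, and two cores cannot show how it would behave on a third.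

The compounds shown leave open whether the same small step would appear if an oxygen atom or a methylene group took the place of the selenium or sulfur atom in the chain. They also leave open what a shorter chain or a third double bond in the tail would do to the numbers in this assay.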